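The source may hold more compounds than are shown below. What is called first, only, known or untested is meant among the compounds shown, and "the series" means these compounds.

Working notes on the series. In a functional assay on HeLa cells (Homo sapiens) for inhibition, read by MTT assay, with a stated time of 48 h (on this read-out higher numbers stand for weaker inhibition of growth and lower numbers for stronger inhibition of growth), compound 1 (`Cn1cc(C2CC(c3ccccc3)=NN2C(=O)c2cccnc2)c2ccccc21`) gives > 10000 nM, which is a limit of the assay and not a number. The change to compound 4 (`Cn1cc(C2CC(c3ccccc3)=NN2C(=O)c2cccnc2Cl)c2ccccc21`) is pyridin-3-yl to 2-chloropyridin-3-yl, with the chloro next to the ring nitrogen: chloro in place of hydrogen on an aromatic carbon.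

Two measured steps from compound 1 bear on this. Chloro in place of hydrogen at a different carbon of the same ring gives compound 2 (`Cn1cc(C2CC(c3ccccc3)=NN2C(=O)c2ccc(Cl)nc2)c2ccccc21`) at 8310 nM, a step of an at least 1.2-fold lower number from compound 1 to compound 2 (0.08 log units; that floor lies within the scatter). Methyl in place of hydrogen gives compound 3 (`Cc1ccc(C(=O)N2N=C(c3ccccc3)CC2c2cn(C)c3ccccc23)cn1`) at 2390 nM, a step of an at least 4.1-fold lower number from compound 1 to compound 3 (0.62 log units; beyond the scatter). The difference between these two is a 3.5-fold lower number from compound 2 to compound 3 (0.54 log units; beyond the scatter).

The closer guide is compound 2, as it carries the same group, with an at least 1.2-fold lower number from compound 1 to compound 2 (0.08 log units; that floor lies within the scatter). A small step toward a lower number is therefore expected, probably not clearly beyond the scatter, and the estimate is an at least 1.3-fold lower number from compound 1 to compound 4 (0.12 log units; that floor lies within the scatter). For compound 4 the estimated value in this assay is 7500 nM, with an expected range of 3000 nM to 18000 nM.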

Compound 4, concentration for 50% growth inhibition: > 10000 nM
Compound 4 gave a limit, no number (the forecaster's own chance of this, stated with the estimate: 40%); middle value at least 1.3-fold (0.12 log units) from the limit.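

In this assay, chloro next to the ring nitrogen and ortho to a large group gives no readable number, and the change from 6-methylpyridin-3-yl to 2-chloropyridin-3-yl gives an at least 4.1-fold higher number from compound 3 to compound 4 (0.62 log units; beyond the scatter). The change from 6-chloropyridin-3-yl to 2-chloropyridin-3-yl gives an at least 1.2-fold higher number from compound 2 to compound 4 (0.08 log units; that floor lies within the scatter), so the series does not yet separate these two chloro positions. The step from compound 1 to compound 4 cannot be read, as both values are limits: the limit of > 10000 nM in this assay, at which 2 of the 4 values shown sit.

As far as these compounds go, whether a smaller or different group at this position, such as fluoro, methoxy or an amine, would give a readable number remains open. Also open, from the compounds shown here alone, is whether methyl at this position would match the value of compound 3, 2390 nM.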